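A Different Ring on the Carbonyl of Compound 1

A few compounds are considered here, and "the series" means these few. Any claim that something is new, unique, unknown or untested is made for them only; others in the source may bear on it.

Compound 1 `CN(C(=O)NC(=O)c1c(F)cccc1F)c1nc(C(F)(F)F)c(C(=O)N/N=C/c2cccc(C(F)(F)F)c2)s1` was tested in a functional assay on HeLa cells (Homo sapiens) for inhibition, read by MTT assay, with a stated time of 72 h (a higher number here means a weaker inhibitor, a lower number a stronger inhibitor), where compound 1 gives 21.6 ug/mL. Among the three compounds measured, this number is the second highest. Compound 2 `Cc1nc(N(C)C(=O)NC(=O)c2c(F)cccc2F)sc1C(=O)N/N=C/c1cccc(C(F)(F)F)c1`, which carries a methyl in place of trifluoromethyl on an aromatic carbon, gives 26.8 ug/mL; the step is a 1.2-fold higher number from compound 1 to compound 2 (0.09 log units; within the scatter). Compound 3 `CN(C(=O)NC(=O)c1c(F)cccc1F)c1nc(C(F)(F)F)c(C(=O)N/N=C/c2cc(C(F)(F)F)cc(C(F)(F)F)c2)s1`, which carries an additional trifluoromethyl on an aromatic carbon elsewhere in the molecule, gives 5.62 ug/mL; the step is a 3.8-fold lower number from compound 1 to compound 3 (0.58 log units; beyond the scatter).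

Compound 4 `CN(C(=O)NC(=O)c1cccc(C(F)(F)F)c1)c1nc(C(F)(F)F)c(C(=O)N/N=C/c2cccc(C(F)(F)F)c2)s1` has not yet been measured. It differs from compound 1 in one place: 3-(trifluoromethyl)phenyl in place of 2,6-difluorophenyl on a carbonyl carbon. Neither measured step touches this part of the molecule. The step to compound 2 altered a group on the shared core and stayed within the scatter, while the step to compound 3 added a trifluoromethyl on a different aromatic ring and lowered the number modestly. The data give no indication of how the ring on the carbonyl carbon affects the read-out, so in this assay the expected change is one of no clear size, within the scatter, as a 1.1-fold lower number from compound 1 to compound 4 (0.03 log units; within the scatter). Compound 4 is therefore estimated at 20 ug/mL, with a range from 8 ug/mL to 50 ug/mL.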

Compound 4, half-maximal inhibitory concentration: 4.81 ug/mL
Beside the measured number, compound 4's estimate is 4.2-fold (0.62 log units) above it, outside the stated range (below it).
By their numbers in this assay, from the lowest: compounds 4 and 3 (each within the scatter of the next); then compounds 1 and 2 (each within the scatter of the next).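

Among the compounds shown here, changing the ring on the carbonyl carbon moves the number in this assay: there is a 4.5-fold lower number from compound 1 to compound 4 (0.65 log units; beyond the scatter), so this part of the molecule, untouched by the earlier compounds, also matters for the read-out. The size of this step is modest, and the step from the shared starting point to the other active analogue, a 3.8-fold lower number from compound 1 to compound 3 (0.58 log units; beyond the scatter), is also modest, so compound 1 can be improved at either end of the molecule. The swap is a double change, since two fluorines leave and a trifluoromethyl enters while the ring grows from 8 to 10 heavy atoms, and no information is available to explain why the number falls.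

On these data alone, it remains open whether the gain comes from losing the fluorines or from gaining the trifluoromethyl, which a plain phenyl ring on the same carbonyl carbon would help to separate. Also open, as far as these compounds go, are how a chlorine, a methoxy group or a saturated cyclohexyl ring would behave there, and whether this change adds to the extra trifluoromethyl of compound 3 when both are placed in one molecule.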